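From ethoxy to butoxy on the ester

A few compounds are considered here, and "the series" means these few. Any claim that something is new, unique, unknown or untested is made for them only; others in the source may bear on it.

Of the compounds shown here, two carry numbers so far in a functional assay on the whole organism (strain Sprague-Dawley) for inhibition, with Rattus norvegicus as the target, with a stated time of 10 min (a higher number here means that more compound is needed for the effect, a lower number that less compound is needed), and they differ from each other in more than one place. Compound 2 (`CCOC(=O)c1cnc(-c2ccccc2OCC)[nH]c1=O`) gives 2 mg/kg and holds the higher of the two numbers. Compound 1 (`CCCCOc1ccccc1-c1ncc(C(=O)O)c(=O)[nH]1`) gives 0.5 mg/kg and so needs less compound, a gap beyond the usual scatter. That gap cannot be assigned to any single structural change.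

Compound 3 (`CCCCOc1ccccc1-c1ncc(C(=O)OCC)c(=O)[nH]1`) follows from compound 2 by one change: ethyl in place of hydrogen on a saturated chain carbon, two bonds along the chain from an oxygen on an aromatic ring. In words, ethyl replaces hydrogen on a saturated chain carbon, two bonds along the chain from an oxygen on an aromatic ring, which turns ethoxy into butoxy. Among the measured compounds shown here, no measured pair isolates this change. The only hint is that butoxy is also present in compound 1 at 0.5 mg/kg with the lower number, which points weakly downward. A modest fall in this assay is therefore expected, most likely not beyond the scatter. The estimated change is a 1.7-fold lower number from compound 2 to compound 3 (0.22 log units; within the scatter) and remains uncertain. For compound 3 the expected value is 1.2 mg/kg within an estimated range from 0.3 mg/kg to 4 mg/kg for now.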

Compound 3, dose for 50% inhibition: 0.5 mg/kg
Compound 3: middle estimate off by 2.4-fold (0.38 log units), on the high side; low and high end bracket the measured number.
By their numbers in this assay, from the lowest: compounds 1 and 3 (each within the scatter of the next); then compound 2.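

In this assay the swap of ethoxy for butoxy now has a measured pair of its own, with all else held constant: ethyl in place of hydrogen on a saturated chain carbon, two bonds along the chain from an oxygen on an aromatic ring, gives a 4.0-fold lower number from compound 2 to compound 3 (0.60 log units; beyond the scatter) and so settles that this chain position affects the dose needed, which the earlier pair, differing in more than one place, could not show. With butoxy in place, ethyl in place of hydrogen on an oxygen next to a carbonyl group gives no change at the digits printed from compound 1 to compound 3 (within the scatter), so the carboxylic acid and the ethyl ester cannot be told apart in this assay. Nothing available on these compounds offers an explanation for either step.

Still open, as far as these compounds go, is whether a longer chain than butyl at this position continues the downward step or reverses it, as two chain lengths give no trend. Also open, from the compounds shown here alone, is whether an amide in place of the ethyl ester keeps the number, and whether a carboxylic acid paired with ethoxy would match the ethyl ester of compound 2 as closely as the butoxy pair match each other.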